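The source may hold more compounds than are shown below. What is called first, only, known or untested is meant among the compounds shown, and "the series" means these compounds.

Measured compounds:
compound 1, `COc1c(C(=O)N[C@H]2CCCC[C@@H]2O)cc(Cc2ccc(C)nc2)c2ccccc12`: 98.4%
compound 2, `COc1c(C(=O)N[C@H]2CCCC[C@@H]2O)cc(Cc2ccc(-n3cccn3)nc2)c2ccccc12`: 98.6%

In an ADME assay on a cell-free system (plasma, Rattus norvegicus) for protein binding, compound 1 gives 98.4% and compound 2 gives 98.6%. For the measured compounds named here, compound 2 thus stands alongside compound 1; the single step between them, a 1.1-fold lower unbound fraction from compound 1 to compound 2 (0.06 log units; within the scatter), is within the scatter, so the two values cannot be told apart on this read-out. Both compounds share the same core and the same amide, and differ only in the group on the aromatic carbon of the ring with one nitrogen.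

Compound 3, `COc1c(C(=O)N[C@H]2CCCC[C@@H]2O)cc(Cc2ccc(-c3cccnc3)nc2)c2ccccc12`, has not yet been measured. It differs from compound 2 in one place: pyridin-3-yl in place of 1H-pyrazol-1-yl on an aromatic carbon. Going by the values given here, the only measured step that bears on this change is a 1.1-fold lower unbound fraction from compound 1 to compound 2 (0.06 log units; within the scatter), which exchanged one group on that aromatic carbon for another without moving the binding beyond the scatter. Another exchange of an aromatic ring on the same aromatic carbon gives no basis for a step beyond the scatter in this assay. For compound 3 the expected step is therefore a 1.2-fold lower unbound fraction from compound 2 to compound 3 (0.07 log units; within the scatter), leaning if anywhere toward slightly higher binding but within the scatter. Compound 3 is estimated at 98.8%, with a range from 97.8% to 99.4%.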

Compound 3, plasma protein binding in the plasma assay: 99.4%
For compound 3 the middle estimate is 2.0-fold (0.30 log units) (unbound fraction) above the measured one, within the range that was stated.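

In the plasma assay compound 3 gives 99.4%, and the aromatic carbon next to the ring nitrogen proves responsive to the group it carries: pyridin-3-yl gives a modest shift relative to both earlier groups (a 2.3-fold lower unbound fraction from compound 2 to compound 3 (0.37 log units; beyond the scatter)) and (a 2.7-fold lower unbound fraction from compound 1 to compound 3 (0.43 log units; beyond the scatter)), whereas the exchange of methyl for 1H-pyrazol-1-yl alone (a 1.1-fold lower unbound fraction from compound 1 to compound 2 (0.06 log units; within the scatter)) could not show that this position matters for this read-out. The change from 1H-pyrazol-1-yl to pyridin-3-yl replaces a five-membered aromatic ring with 2 hetero atoms by a six-membered aromatic ring with 1 hetero atom, and in a physicochemical assay for permeability (on this read-out higher numbers stand for higher permeability and lower numbers for lower permeability), compound 2 gives 31 10^-6 cm/s and compound 3 gives 28 10^-6 cm/s, so the same exchange gives only a small difference (a 1.1-fold lower number from compound 2 to compound 3 (0.04 log units; within the scatter)), and of these two read-outs only the plasma assay separates compound 2 from compound 3. Nothing available accounts for the shift in binding.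

With only these three compounds, the contributions of ring size, of the number of hetero atoms and of where the ring nitrogen sits in the entering group cannot be separated. Also open, as far as these compounds go, is how the plasma assay would respond to an amine, a carboxylic acid or a longer chain on this aromatic carbon, including whether any of them would move the read-out downward from the level of compound 1.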